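Demethylation step on the hydrazone aryl ring, second instance

The source may hold more compounds than are shown below. What is called first, only, known or untested is meant among the compounds shown, and "the series" means these compounds.

Compound 1 `COc1cc(/C=N/NC(=O)CCCc2nc3ccccc3c(=O)[nH]2)cc(OC)c1O`, compound 2 `COc1cc(/C=N/NC(=O)CCCc2nc3ccccc3c(=O)[nH]2)cc(O)c1O` and compound 3 `COc1ccc(/C=N/NC(=O)CCCc2nc3ccccc3c(=O)[nH]2)cc1` share the same core and differ only in the aryl ring attached through the hydrazone. In a physicochemical assay, read by spectrophotometry, with a stated time of 6 min (on this read-out lower numbers stand for stronger inhibition and higher numbers for weaker inhibition), compound 1 gives 135000000 nM, compound 2 gives 50000000 nM and compound 3 gives 180000000 nM. Compound 2 differs from compound 1 by hydrogen in place of methyl on an oxygen on an aromatic ring, and this change produced a 2.7-fold lower number from compound 1 to compound 2 (0.43 log units; beyond the scatter). The difference between compound 1 and compound 3 is not broken down here; their two values lie within the scatter of each other.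

Compound 4 `O=C(CCCc1nc2ccccc2c(=O)[nH]1)N/N=C/c1ccc(O)cc1` is not yet measured. Among the measured compounds shown here, it differs from compound 3 by hydrogen in place of methyl on an oxygen on an aromatic ring, the same change as the one between compound 1 and compound 2, at a place described in the same words. For the measured compounds named here, only that one measured step exists for this change, so the expectation rests on it alone. For compound 4 the expected step is a 2.7-fold lower number from compound 3 to compound 4 (0.43 log units; beyond the scatter), set beside the measured 2.7-fold lower number from compound 1 to compound 2 (0.43 log units; beyond the scatter). Compound 4 is therefore estimated at 67000000 nM in this assay, with an expected range from 30000000 nM to 150000000 nM.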

Compound 4, half-maximal inhibitory concentration: 170000000 nM
For compound 4 the middle estimate is 2.5-fold (0.40 log units) below the measured one; the whole stated range lies below it.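

In this assay, the change from methoxy to hydroxy on the 4-methoxyphenyl ring gives a 1.1-fold lower number from compound 3 to compound 4 (0.02 log units; within the scatter), whereas the same replacement of methyl by hydrogen gave a 2.7-fold lower number from compound 1 to compound 2 (0.43 log units; beyond the scatter), so the step seen on one aryl ring did not carry over to the other, even on the shared core. With a single step on each ring, this shows that the change has no fixed size across these two rings, but it does not show which feature of the rings separates the two outcomes, nor how the change would behave on a different core. No measurement shown here accounts for the difference between the two steps.

Going by these compounds, it remains open whether the larger step depends on the further oxygen-bearing groups on the ring of compound 1 and compound 2, which the ring of compound 3 lacks. Also open, on these data alone, is how an amine or a carboxylic acid in place of the hydroxy of compound 4 would read in this assay.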